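The source may report more compounds than this note shows. Statements on the series, on what has been measured and on what is new or still open speak of the compounds shown alone.

Of the compounds shown here, two have been measured in an assay on CHO cells with Alpha-1A adrenergic receptor (Homo sapiens) as the target; a higher number here means a weaker inhibitor, a lower number a stronger inhibitor. Compound 1 `COCC1=C(C(=O)NCCCN2CCC(c3ccccn3)CC2)[C@@H](c2ccc(F)c(F)c2)NC(=O)N1` gives 0.45 nM. Compound 2 `CC(=O)N1C(=O)N(C)C(C)=C(C(=O)NCCCN2CCC(c3ccc(F)cc3)CC2)[C@H]1c1ccc(F)c(F)c1` gives 2.2 nM, the higher of the two numbers, and the gap between these two values lies beyond the usual scatter. Compound 3 `COC(=O)N1C(=O)N(C)C(C)=C(C(=O)NCCCN2CCC(c3ccc(F)cc3)CC2)[C@H]1c1ccc(F)c(F)c1` differs from compound 2 in a single place: methoxy in place of methyl on a carbonyl carbon, which, read one bond further out, is acetyl to methoxycarbonyl. Within the data shown here, no measured step of this kind exists here, so only a small change is expected, probably none beyond the scatter, with no clear direction. The expected step is a 1.1-fold higher number from compound 2 to compound 3 (0.06 log units; within the scatter). Compound 3 is therefore estimated to give 2.5 nM, within a range of 1 nM to 6 nM.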

Compound 3, inhibition constant: 0.75 nM
Beside the measured number, compound 3's estimate is 3.3-fold (0.52 log units) above it; measured number outside the range, below it.
By their numbers in this assay, from the lowest: compounds 1 and 3 (each within the scatter of the next); then compound 2.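

In this assay, the group on this carbonyl carbon clearly matters: methoxy in place of methyl, which reads as acetyl to methoxycarbonyl, gives a 2.9-fold lower number from compound 2 to compound 3 (0.47 log units; beyond the scatter). So even this small edit at this position moves the number beyond the usual scatter, and in the direction of a stronger inhibitor. No measurement at hand explains why this step occurs. On these data alone, whether ethoxy or dimethylamino in place of the methoxy would lower the number further remains open. A single step also cannot show whether this change would have the same effect on another core.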